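The source may report more compounds than this note shows. Statements on the series, on what has been measured and on what is new or still open speak of the compounds shown alone.

Measured so far:
- compound 1 `CCCCCCCCc1ccc(OCC(=O)Cn2nnc(-c3ccc(C(=O)OC)cc3)n2)cc1`: 29 nM in an assay on microsomes from brain for inhibition of Fatty-acid amide hydrolase 1 (Rattus norvegicus), read by fluorescence and HPLC, with a stated time of 60 min; a lower number here means a stronger inhibitor, a higher number a weaker inhibitor
- compound 2 `CCCCCCCCc1ccc(OCC(=O)Cn2nnc(-c3ccccn3)n2)cc1`: 18 nM in this assay

Of the two numbers in this assay, compound 2 gives the lower one, but the gap between them is a 1.6-fold lower number from compound 1 to compound 2 (0.21 log units; within the scatter), so the two compounds cannot be ranked against each other.

Compound 3 `CCCCCCCCc1ccc(OCC(=O)Cn2nnc(C(=O)O)n2)cc1` has not been measured in this assay. It differs from compound 2 by carboxy in place of pyridin-2-yl on an aromatic carbon.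

Within the data shown here, the one measured step, from compound 1 to compound 2, swaps one aromatic substituent on the same ring carbon for another and stays within the scatter. Among the measured compounds shown here, no measured step removes the aromatic group from that carbon altogether, so nothing here bears directly on the change to compound 3, and the expectation rests only on the size of what leaves and what enters. For compound 3 a weaker result is expected, a step of a 17-fold higher number from compound 2 to compound 3 (1.22 log units; beyond the scatter) beyond the scatter, with the estimate for compound 3 in this assay put at 300 nM within a range of 60 nM to 2000 nM.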

Compound 3, half-maximal inhibitory concentration: 41 nM
For compound 3 the middle estimate is 7.3-fold (0.86 log units) above the measured one; the measured number lies below the stated range.
By their numbers in this assay, from the lowest: compounds 2, 1 and 3 (each within the scatter of the next, the first and the last beyond it).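

In this assay, carboxy in place of pyridin-2-yl on the aromatic carbon of the five-membered aromatic ring with 4 nitrogen gives a 2.3-fold higher number from compound 2 to compound 3 (0.36 log units; beyond the scatter) as a modest step, and carboxy in place of 4-(methoxycarbonyl)phenyl gives a 1.4-fold higher number from compound 1 to compound 3 (0.15 log units; within the scatter) with no order to be drawn between that pair. Among these compounds, the earlier compounds carried only ring-bearing groups on this carbon, whereas this result shows that a group with no ring and fewer heavy atoms can stand there at a cost that is small in the one step beyond the scatter and unreadable in the other, so an aromatic ring on this carbon is not needed to keep the value in the same general region. No measurement at hand explains this tolerance of the position.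

From the compounds shown here alone, whether the acidic hydrogen of the carboxy group matters stays open, since a methyl ester or a primary amide on this carbon would be needed to separate it from the carbonyl. Going by these compounds, it is also open whether a simple amine or a bare hydrogen at this place would hold the value as carboxy does.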